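The source may report more compounds than this note shows. Statements on the series, on what has been measured and on what is new or still open speak of the compounds shown alone.

Measured compounds:
compound 1 `O=C(/C=C/c1ccccc1)c1ccc[nH]1` gives only a limit of the assay in a functional assay on HL-60 cells (Homo sapiens) for inhibition, read by MTT assay, with a stated time of 48 h (on this read-out lower numbers stand for stronger inhibition and higher numbers for weaker inhibition), namely > 100000 nM.
compound 2 `O=C(/C=C/c1ccc(Cl)cc1)c1ccc[nH]1` gives 13000 nM in this assay.
compound 3 `O=C(/C=C/c1ccc(Cl)cc1)c1ccco1` gives 19000 nM in this assay.

Among the two numbers shown, compound 3 carries the higher one, though its nearest neighbour, compound 2, lies at a 1.5-fold higher number from compound 2 to compound 3 (0.16 log units; within the scatter), a gap within the scatter. The third value is a limit only (the limit of > 100000 nM in this assay, at which 1 of the 3 values shown sits).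

Compound 4 `CN(C)c1ccc(/C=C/C(=O)c2ccco2)cc1` differs from compound 3 by dimethylamino in place of chloro on an aromatic carbon. Within the data shown here, of the measured steps, only one concerns this chloro group: chloro in place of hydrogen gave an at least 7.6-fold lower number from compound 1 to compound 2 (0.88 log units; beyond the scatter), the one step beyond the scatter in the whole set. The other step, a 1.5-fold higher number from compound 2 to compound 3 (0.16 log units; within the scatter), changes the ring on the carbonyl carbon and speaks only for the core shared by compound 3 and compound 4. Among the measured compounds shown here, no measured step replaces chloro by dimethylamino, so the data give no direction for this change. The step from compound 3 to compound 4 in this assay is therefore expected to be a 1.1-fold higher number from compound 3 to compound 4 (0.02 log units; within the scatter), that is, nothing beyond the scatter, but with a wide margin either way. Compound 4 is estimated at 20000 nM, between 5000 nM and 80000 nM.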

Compound 4, half-maximal inhibitory concentration: 12000 nM
The estimate for compound 4 lay 1.7-fold (0.22 log units) above the measured number; low and high end bracket the measured number.
By their numbers in this assay, from the lowest: compounds 4, 2 and 3 (each within the scatter of the next). At a limit, above all of these: compound 1.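

At this position, on an aromatic carbon para to a group of 9 heavy atoms, the change gives a 1.6-fold lower number from compound 3 to compound 4 (0.20 log units; within the scatter) in this assay and so stays within the scatter, even though dimethylamino brings 3 heavy atoms and 1 hydrogen-bond acceptor where chloro had a single chlorine atom. Among these compounds, the only earlier step at this position was an at least 7.6-fold lower number from compound 1 to compound 2 (0.88 log units; beyond the scatter) and it set chloro against hydrogen on the 1H-pyrrol-2-yl side, whereas this step sets two groups against each other on the furan-2-yl side and shows that chloro is not the only group here that gives a number in this range. Nothing shown gives a cause for this closeness of chloro and dimethylamino.

The compounds shown leave open how hydrogen at this position behaves on the furan-2-yl side, and whether dimethylamino gives a similar number on the 1H-pyrrol-2-yl side. They also leave open how a primary amine, a methoxy group, a carboxylic acid or a longer alkyl chain would compare at this position.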